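From 2-hydroxyphenyl to 4-methoxyphenyl: what to expect

A few compounds are considered here, and "the series" means these few. Any claim that something is new, unique, unknown or untested is made for them only; others in the source may bear on it.

Compounds measured in a functional assay on HL-60 cells (Homo sapiens) for cytotoxicity, read by MTT assay; on this read-out higher numbers stand for weaker inhibition and lower numbers for stronger inhibition:
Compound 1 `O=C(N/N=C/c1ccccc1)c1cn(C2CC2)c2cc(N3CCNCC3)c(F)cc2c1=O`: 25000 nM
Compound 2 `O=C(N/N=C/c1ccccc1O)c1cn(C2CC2)c2cc(N3CCNCC3)c(F)cc2c1=O`: 25000 nM

Among the measured compounds shown here, compound 2 stands level with compound 1, its only neighbour on these numbers. Compound 3 `COc1ccc(/C=N/NC(=O)c2cn(C3CC3)c3cc(N4CCNCC4)c(F)cc3c2=O)cc1` has not yet been measured. Its difference from compound 2 is this: 4-methoxyphenyl in place of 2-hydroxyphenyl on a carbon with a double bond to nitrogen. Thus 4-methoxyphenyl stands in place of 2-hydroxyphenyl on a carbon with a double bond to nitrogen. For the measured compounds named here, only one measured step bears on this change: no change at the digits printed from compound 1 to compound 2 (within the scatter), where hydroxy replaced hydrogen on an aromatic carbon. Going by the values given here, it is a single, different change, and no measured compound carries a methoxy group, so the guidance is thin. Among the compounds with values here, with that step as the only guide, no shift beyond the scatter is expected in this assay. The expected step is no change at the digits printed from compound 2 to compound 3 (within the scatter). The estimate for compound 3 is 25000 nM, with an expected range of 10000 nM to 50000 nM.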

Compound 3, half-maximal inhibitory concentration: 25000 nM
The estimate for compound 3 equals the measured number at the digits printed, and the stated range covers the measured number.
By their numbers in this assay, from the lowest: compounds 1, 2 and 3 (each within the scatter of the next).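

In this assay, exchanging the 2-hydroxyphenyl group for a 4-methoxyphenyl group gave no change at the digits printed from compound 2 to compound 3 (within the scatter), and adding a methoxy group where there had been none gave no change at the digits printed from compound 1 to compound 3 (within the scatter). The earlier pair covered only a hydroxy group, whereas this result extends the unchanged read-out to a methoxy group and to a substituent with 0 hydrogen-bond donors, against 1 for 2-hydroxyphenyl. Nothing available explains this lack of change.

The compounds shown leave open whether an amine, a carboxylic acid or a longer alkoxy chain on the phenyl ring would shift the value beyond the scatter. They also leave open what a saturated ring such as cyclohexyl would do in place of the phenyl ring.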